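The source may hold more compounds than are shown below. What is called first, only, known or untested is meant among the compounds shown, and "the series" means these compounds.

Values in a functional assay on HL-60 cells (Homo sapiens) for antiproliferative activity, read by MTT assay (on this read-out higher numbers stand for weaker inhibition and lower numbers for stronger inhibition), each one a limit of the assay and not a number:

Compound 1 `COc1ccc(/C=N/NC(=O)c2cn(C3CC3)c3cc(N/N=C/c4ccc(OC)c(O)c4)c(F)cc3c2=O)cc1O`: <= 25000 nM
Compound 2 `O=C(N/N=C/c1ccc(F)cc1)c1cn(C2CC2)c2cc(N/N=C/c3ccc(F)cc3)c(F)cc2c1=O`: <= 25000 nM
Compound 3 `O=C(N/N=C/c1ccccc1)c1cn(C2CC2)c2cc(N3CCNCC3)c(F)cc2c1=O`: <= 25000 nM

The starting point is compound 3, and its entry is <= 25000 nM. That entry is a limit, so it does not give an exact potency. Compound 3 has no special place in the set, as the whole series shows (the limit of <= 25000 nM in this assay, at which 3 of the 3 values shown sit). Among the measured compounds shown here, no measured compound can therefore be ranked above another.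

Compound 4 `O=C(N/N=C/c1ccccc1[N+](=O)[O-])c1cn(C2CC2)c2cc(N3CCNCC3)c(F)cc2c1=O` changes compound 3 in one place: nitro in place of hydrogen on an aromatic carbon. In words, nitro takes the place of hydrogen on an aromatic carbon, ortho to a large group, turning phenyl into 2-nitrophenyl. The rest of the molecule stays the same.

For the measured compounds named here, no pair of measured compounds differs by a single change, so the data contain no direct guide to what this swap does. With so little to go on, the sensible default is to expect no shift beyond the usual scatter of repeated measurements. The expected change, a step that the limit leaves unreadable from compound 3 to compound 4, is estimated on that basis. Compound 4 may well be reported as a limit too. For compound 4 the estimated value is 15000 nM, with an expected range of 3000 nM to 25000 nM.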

Compound 4, half-maximal inhibitory concentration: <= 25000 nM
Compound 4 was reported as a limit (the forecaster's own chance of this, stated with the estimate: 60%); the middle value does not contradict the limit.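

No step can be read from compound 3 to compound 4, because each of their entries in this assay is a limit of the assay and not a number: the limit of <= 25000 nM in this assay, at which 4 of the 4 values shown sit.

The compounds shown leave open whether turning phenyl into 2-nitrophenyl changes potency at all, and how these four compounds rank against one another.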